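Sulfonamide beta-amino acids: nitrile for trifluoromethyl

A few compounds are considered here, and "the series" means these few. Any claim that something is new, unique, unknown or untested is made for them only; others in the source may bear on it.

Three members of the series have been run in a functional assay on MDA-MB-436 cells (Homo sapiens) for antiproliferative activity, read by MTT assay, with a stated time of 24 h; on this read-out higher numbers stand for weaker inhibition and lower numbers for stronger inhibition. Compound 2 `O=C(O)CC(NS(=O)(=O)c1ccc(C(F)(F)F)cc1)c1ccccc1F` gives 55600 nM. Compound 1 `N#Cc1ccc(S(=O)(=O)NC(CC(=O)O)c2ccccc2F)cc1` differs from compound 2 by cyano in place of trifluoromethyl on an aromatic carbon; compound 1 gives 77700 nM. The step is a 1.4-fold higher number from compound 2 to compound 1 (0.15 log units; within the scatter). Compound 3 `O=C(O)CC(NS(=O)(=O)c1ccc(C(F)(F)F)cc1)c1ccc(Cl)cc1Cl` differs from compound 2 by 2,4-dichlorophenyl in place of 2-fluorophenyl on a saturated chain carbon bound to a saturated chain carbon and a sulfonamide nitrogen; compound 3 gives 37600 nM. The step is a 1.5-fold lower number from compound 2 to compound 3 (0.17 log units; within the scatter). Only the gap between compound 3 and compound 1 lies beyond the scatter, so no order is drawn between compound 3 and compound 2.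

Compound 4 `N#Cc1ccc(S(=O)(=O)NC(CC(=O)O)c2ccc(Cl)cc2Cl)cc1` has not yet been measured. It differs from compound 3 by cyano in place of trifluoromethyl on an aromatic carbon. The same change is made from compound 2 to compound 1, so it occurs twice among the compounds shown. The two place descriptions agree word for word, so this is the same change carried onto a second core, and the two cores differ as described by 2,4-dichlorophenyl in place of 2-fluorophenyl on a saturated chain carbon bound to a saturated chain carbon and a sulfonamide nitrogen. Going by the values given here, the only precedent is the step of a 1.4-fold higher number from compound 2 to compound 1 (0.15 log units; within the scatter), which lies within the scatter, and no further instance is available to test whether the core alters it. In this assay the step expected for compound 4 is a 1.4-fold higher number from compound 3 to compound 4 (0.14 log units; within the scatter), resting on the earlier step of a 1.4-fold higher number from compound 2 to compound 1 (0.15 log units; within the scatter). Compound 4 is therefore estimated to give 52000 nM in this assay. The expected range for compound 4 runs from 30000 nM to 95000 nM.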

Compound 4, half-maximal inhibitory concentration: 19800 nM
For compound 4 the middle estimate is 2.6-fold (0.42 log units) above the measured one; measured number outside the range, below it.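

In this assay, nitrile in place of trifluoromethyl on the core carrying 2,4-dichlorophenyl gives a 1.9-fold lower number from compound 3 to compound 4 (0.28 log units; within the scatter), and set beside the same change on the core carrying 2-fluorophenyl, the two steps do not separate: the same change on two cores in this assay, a 1.4-fold higher number (0.15 log units; within the scatter) from compound 2 to compound 1 and a 1.9-fold lower number (0.28 log units; within the scatter) from compound 3 to compound 4, 2.7-fold (0.42 log units) apart, within the scatter of two such steps. Going by these compounds alone, the other change in the square, 2,4-dichlorophenyl in place of 2-fluorophenyl, gives a 3.9-fold lower number from compound 1 to compound 4 (0.59 log units; beyond the scatter), the only step here beyond the scatter, yet it does not separate from its counterpart on the trifluoromethyl core either: the same change on two cores in this assay, a 1.5-fold lower number (0.17 log units; within the scatter) from compound 2 to compound 3 and a 3.9-fold lower number (0.59 log units; beyond the scatter) from compound 1 to compound 4, 2.7-fold (0.42 log units) apart, within the scatter of two such steps. The square therefore fits a nitrile exchange that carries from one core to the other without a detectable dependence on the core, but it does not show that the exchange transfers reliably, since it rests on two pairs, neither nitrile step lies beyond the scatter, and a modest core dependence cannot be excluded.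

Still open, from the compounds shown here alone, is whether the aryl exchange holds its size with other groups on the sulfonyl-bound ring, such as a methoxy group or an amine in the place of the nitrile. Also open, going by these compounds, is how the series responds to a primary amide in place of the carboxylic acid, or to a longer chain leading to it.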